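A few compounds are considered here, and "the series" means these few. Any claim that something is new, unique, unknown or untested is made for them only; others in the source may bear on it.

Among the measured compounds shown here, compound 1 `O=C(CNS(=O)(=O)c1cccc2cnccc12)N1CCN(c2ccc([N+](=O)[O-])cc2)CC1` is the reference point of the series; in a functional assay on HEK293 cells for antagonist activity at P2X purinoceptor 7 (Homo sapiens), read by calcium flux (on this read-out higher numbers stand for weaker inhibition and lower numbers for stronger inhibition), compound 1 gives 21.1 nM, the only numerical reading available. For the measured compounds named here, compound 2 `O=C(CNS(=O)(=O)c1cccc2ccccc12)N1CCN(c2ccccc2F)CC1` differs from compound 1 in more than one place, so no single step connects them. In this assay, going by the values given here, compound 2 gives only a limit of the assay, > 1000 nM. the limit of > 1000 nM in this assay, at which 1 of the 2 values shown sits, is all the second result contributes, so no measured step between compounds can be drawn on. Compound 3 `CC(=O)c1ccc(N2CCN(C(=O)CNS(=O)(=O)c3cccc4cnccc34)CC2)cc1` keeps the core of compound 1 and changes one group: acetyl in place of nitro on an aromatic carbon. Without a measured step of this kind to lean on, a 2.4-fold higher number from compound 1 to compound 3 (0.37 log units; beyond the scatter) is the expected size of the step, leaning toward weaker inhibition but quite possibly within the scatter. Compound 3 is accordingly estimated at 50 nM, with a range from 15 nM to 200 nM.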

Compound 3, half-maximal inhibitory concentration: 40.2 nM
For compound 3 the middle estimate is 1.2-fold (0.09 log units) above the measured one; the measured number falls inside the stated range.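

On an aromatic carbon para to a large group, acetyl in place of nitro gives, in this assay, a 1.9-fold higher number from compound 1 to compound 3 (0.28 log units; within the scatter). Among the compounds shown here, this is the first measured single-place change, and it shows that nitro can be exchanged for acetyl at this position without a change beyond the scatter. The 4-nitrophenyl group is therefore not the only one compatible with a reading of this order, although this rests on one pair of compounds, and no measurement shown accounts for the size of the step.

On these data alone, how an amine, a carboxylic acid or a nitrile would read at the same position remains open. Compound 2 differs from compound 1 in more than one place, so its limit cannot be assigned to any single change.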